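From 3-methylpiperidin-1-yl to 4-methylpiperidin-1-yl

A few compounds are considered here, and "the series" means these few. Any claim that something is new, unique, unknown or untested is made for them only; others in the source may bear on it.

Measured so far in an ADME assay on MT4 cells (Homo sapiens) for cytotoxicity, read by MTT assay, with a stated time of 4 days (a higher number here means that more compound is tolerated, a lower number that less compound is tolerated), for two compounds:
- Compound 1 `CCCN(C)c1nc(Cc2c(F)cccc2F)cc(=O)[nH]1` with 85000 nM as a number
- Compound 2 `CC1CCCN(c2nc(Cc3c(F)cccc3F)cc(=O)[nH]2)C1` with > 78000 nM as a limit

Compound 2 stands at > 78000 nM which is a limit of the assay and not a number. Among the measured compounds shown here, the only measured change is a step that the limit leaves unreadable from compound 1 to compound 2 and gives no size to carry over. Compound 3 `CC1CCN(c2nc(Cc3c(F)cccc3F)cc(=O)[nH]2)CC1` has 4-methylpiperidin-1-yl in place of 3-methylpiperidin-1-yl on an aromatic carbon with the same atoms joined differently. Only a step within the scatter is expected in this assay. The estimate leans on compound 1 with its 85000 nM reading. The estimate means a step that the limit leaves unreadable from compound 2 to compound 3 as the expected change. Compound 3 is expected at 85000 nM with an estimated range from 40000 nM to 180000 nM around it.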

Compound 3, half-maximal cytotoxic concentration: > 78000 nM
Compound 3: no number, only a limit; the forecaster's own chance of this, stated with the estimate: 60%; the middle value is on the limit's open side.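

No step can be read from compound 2 to compound 3 or from compound 1 to compound 3, because compound 2 and compound 3 each give only a limit and not a number: the limit of > 78000 nM in this assay, at which 2 of the 3 values shown sit.

The compounds shown leave open whether 3-methylpiperidin-1-yl and 4-methylpiperidin-1-yl differ in how much compound is tolerated, and how either compares with methyl(propyl)amino.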